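Series notes: methoxymethyl for fluoro on the aryl-alkyne arm

The source may report more compounds than this note shows. Statements on the series, on what has been measured and on what is new or still open speak of the compounds shown alone.

Measured compounds:
compound 1, `O=C(O)COc1ccc(Cl)cc1C#Cc1ccc(F)cc1F`: 101 nM
compound 2, `CCS(=O)(=O)c1ccc(C)c(C#Cc2cc(Cl)ccc2OCC(=O)O)c1`: 8.6 nM
compound 3, `Cc1ccc(S(=O)(=O)CC(C)C)cc1C#Cc1cc(Cl)ccc1OCC(=O)O`: 3 nM

In an assay on CHO cells for displacement of a labelled ligand from prostaglandin D2 receptor 2 (Homo sapiens), read by scintillation counting (on this read-out lower numbers stand for stronger inhibition and higher numbers for weaker inhibition), compound 1 gives the highest number of the three. Compound 2 sits a 2.9-fold lower number from compound 2 to compound 3 (0.46 log units; beyond the scatter) above compound 3, and compound 1 stands well above both, the gaps to compound 2 and to compound 3 each being beyond the scatter.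

Compound 4, `COCc1ccc(C#Cc2cc(Cl)ccc2OCC(=O)O)c(F)c1`, is not yet measured. The change from compound 1 is methoxymethyl in place of fluoro on an aromatic carbon.

Within the data shown here, no measured step bears directly on this change. Among the measured compounds shown here, the only step with a single difference, compound 2 to compound 3, concerns the group bound to a sulfonyl sulfur, not the aromatic carbon altered here; it is modest in size. Compounds 2 and 3 show that an aryl arm without fluoro can give much lower numbers than compound 1, but their sulfonyl groups are absent from compound 4, so this is not transferable. A step no larger than the scatter, or a small drop, is expected for compound 4, estimated as a 1.4-fold lower number from compound 1 to compound 4 (0.16 log units; within the scatter).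

Compound 4 is therefore expected to give about 70 nM in this assay, within the range 25 nM to 250 nM.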

Compound 4, inhibition constant: 22 nM
The estimate for compound 4 lay 3.2-fold (0.50 log units) above the measured number, outside the stated range (below it).
By their numbers in this assay, from the lowest: compound 3; then compound 2; then compound 4; then compound 1.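

In this assay, methoxymethyl in place of fluoro on this aromatic carbon, meta to a fluoro group and para to a large group, gives a 4.6-fold lower number from compound 1 to compound 4 (0.66 log units; beyond the scatter) as a step beyond the scatter. Among these compounds, this is the first single-place reading at this carbon, and it shows that the position accepts a group of more heavy atoms than fluoro, with the number moving down and no sulfonyl group present. No measurement on hand accounts for the size of this step, so it stays unassigned among the loss of fluoro, the added carbons and the added oxygen.

Still open, from the compounds shown here alone, is whether the oxygen of methoxymethyl matters or the chain alone does, which a propyl chain, a hydroxymethyl group or an aminomethyl group on this carbon would separate. Also open, going by these compounds, is whether the remaining fluoro contributes to the number at all.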